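Furan-2-yl in place of naphthalen-1-yl: working notes

This account rests on a few compounds, and the source may have more. Where it says the series, first, only, none or still open, it means among the compounds named here.

Measured so far in a functional assay on HCT-116 cells (Homo sapiens) for inhibition, read by sulforhodamine B assay, with a stated time of 48 h, tested at 50 uM; a lower number here means less inhibition of growth, a higher number more inhibition of growth at the concentration tested:
- compound 1 `COc1cc(/C=C/C(=O)/C=C/c2cccc3ccccc23)ccc1OCc1cn(CCOc2cc(=O)oc3ccccc23)nn1` gives 83%
- compound 2 `COc1cc(/C=C/C(=O)/C=C/c2cccs2)ccc1OCc1cn(CCCCCOc2cc(=O)oc3ccccc23)nn1` gives 31%

Compound 1 holds the higher of the two numbers, and compound 2 lies below it, beyond the scatter. These two compounds differ in more than one place, so no single change can be read from them. Compound 3 `COc1cc(/C=C/C(=O)/C=C/c2ccco2)ccc1OCc1cn(CCOc2cc(=O)oc3ccccc23)nn1` is next, with furan-2-yl in place of naphthalen-1-yl on a double-bonded chain carbon bound to a double-bonded chain carbon. Within the data shown here, no measured step covers this change. In this assay a drop is expected, with the estimated step (a number 23 percentage points lower from compound 1 to compound 3 (beyond the scatter)) probably beyond the scatter. Compound 3 is expected at 60% in an estimated range of 35% to 82% for now.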

Compound 3, percent growth inhibition at one concentration: 72%
Compound 3: middle estimate off by 12 percentage points, on the low side; measured number inside the range.
By their numbers in this assay, from the lowest: compound 2; then compound 3; then compound 1.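

In this assay, among these compounds, the step of a number 11 percentage points lower from compound 1 to compound 3 (beyond the scatter) is the first single-change reading at this position, on a double-bonded chain carbon bound to a double-bonded chain carbon. The two six-membered aromatic rings of naphthalen-1-yl are not required for a high number here, since compound 3 with furan-2-yl still gives 72% at the concentration tested. No evidence on the cause of this step is at hand.

Open, going by these compounds, is how phenyl, or an aromatic ring carrying an amine, would read at this position. Also open, on these data alone, is whether the step holds with a longer chain elsewhere on the shared core.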